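The source may report more compounds than this note shows. Statements on the series, on what has been measured and on what is new or still open speak of the compounds shown alone.

Compound 1: `COc1cc(C(=O)NS(=O)(=O)c2ccccc2)ccc1Cc1cn(C)c2ccc(NC(=O)OC3CCCC3)cc12` — 9.69
Compound 2: `COc1cc(C(=O)O)ccc1Cc1cn(C2CCCC2)c2ccc(NC(=O)OC3CCCC3)cc12` — 7.67

In an assay on isolated protein (Cavia porcellus) with cysteinyl leukotriene receptor (Homo sapiens) as the target (on this read-out higher numbers stand for higher potency (the scale is a negative logarithm) and lower numbers for lower potency), compound 2 gives 7.67, the lower of the two numbers; compound 1 sits higher by a margin beyond the scatter. For the measured compounds named here, compounds 1 and 2 differ from each other in more than one place, so no single-change step between measured compounds is known, and the gap between them cannot be assigned to either difference alone.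

Compound 3 `COc1cc(C(=O)NS(=O)(=O)c2ccccc2)ccc1Cc1cn(C2CCCC2)c2ccc(NC(=O)OC3CCCC3)cc12` has not been measured. It differs from compound 2 by (phenylsulfonyl)amino in place of hydroxy on a carbonyl carbon. An upward step beyond the scatter is expected because compound 1 carries the same (phenylsulfonyl)carbamoyl group and gives 9.69. For compound 3 the expected step is a number 1.23 log units higher from compound 2 to compound 3 (beyond the scatter). Compound 3 is estimated at 8.9, with a range of 8.2 to 9.7.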

Compound 3, negative logarithm of the antagonist equilibrium constant: 7.84
For compound 3 the middle estimate is 1.06 log units above the measured one, outside the stated range (below it).
By their numbers in this assay, from the lowest: compounds 2 and 3 (each within the scatter of the next); then compound 1.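

With cyclopentyl on the aromatic nitrogen, in this assay the change from carboxy to (phenylsulfonyl)carbamoyl gives a number 0.17 log units higher from compound 2 to compound 3 (within the scatter) and so does not separate the two compounds. With the (phenylsulfonyl)carbamoyl group held, cyclopentyl in place of methyl on the aromatic nitrogen gives a number 1.85 log units lower from compound 1 to compound 3 (beyond the scatter) and shows that the (phenylsulfonyl)carbamoyl group alone does not carry the high number of compound 1. No measured data bear on why either step has this size.

Still open is whether the carboxy to (phenylsulfonyl)carbamoyl change has a larger effect with methyl on the aromatic nitrogen, as the carboxylic acid carrying that methyl is absent from the compounds shown. On these data alone, how an ethyl or isopropyl group on that nitrogen would stand relative to methyl and cyclopentyl also remains open.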